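Benzothiazole hydrazones: moving the methoxy group

The source may hold more compounds than are shown below. What is called first, only, known or untested is meant among the compounds shown, and "the series" means these compounds.

Two compounds of the series have numbers in an assay on isolated protein for inhibition of Maltase-glucoamylase (Homo sapiens), with a stated time of 15 min; a lower number here means a stronger inhibitor, a higher number a weaker inhibitor. Compound 1 `COc1ccc(/C=N/NC(=O)c2ccc(-c3nc4ccccc4s3)cc2)c(O)c1` gives 6970 nM. Within the data shown here, compound 2 `COc1ccc(/C=N/NC(=O)c2ccc(-c3nc4ccccc4s3)cc2)cc1`, which lacks the hydroxy group, gives 18300 nM and stands as the higher of the two numbers; the step of a 2.6-fold higher number from compound 1 to compound 2 (0.42 log units; beyond the scatter) is the only measured step so far.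

Compound 3 `COc1cccc(/C=N/NC(=O)c2ccc(-c3nc4ccccc4s3)cc2)c1` is not yet measured. It differs from compound 2 by 3-methoxyphenyl in place of 4-methoxyphenyl on a carbon with a double bond to nitrogen, so the same atoms are present and only the place of the methoxy group on that ring changes. Among the measured compounds shown here, no measured step bears on this change: the one step known, from compound 1 to compound 2, concerns a hydroxy group, not the position of the methoxy group. With nothing to point in either direction, the expected step of a 1.0-fold lower number from compound 2 to compound 3 (0.01 log units; within the scatter) is none beyond the scatter. Compound 3 is therefore estimated at 18000 nM, within 7000 nM to 45000 nM.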

Compound 3, half-maximal inhibitory concentration: 11100 nM
Compound 3: middle estimate off by 1.6-fold (0.21 log units), on the high side; measured number inside the range.
By their numbers in this assay, from the lowest: compounds 1, 3 and 2 (each within the scatter of the next, the first and the last beyond it).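

In this assay, 3-methoxyphenyl in place of 4-methoxyphenyl on a carbon with a double bond to nitrogen gives a step that the scatter cannot separate (a 1.6-fold lower number from compound 2 to compound 3 (0.22 log units; within the scatter)), so this change of place, with the same atoms, has no resolved effect on the number. Compound 3 also cannot be separated from compound 1 (a 1.6-fold higher number from compound 1 to compound 3 (0.20 log units; within the scatter)), although the step between compound 1 and compound 2 lies beyond the scatter (a 2.6-fold higher number from compound 1 to compound 2 (0.42 log units; beyond the scatter)), so compound 3 does not settle where it belongs relative to that pair. No measured evidence on these compounds bears on this result.

Still open, from the compounds shown here alone, is whether an amine or a carboxylic acid in place of the methoxy group on this ring would give a step beyond the scatter. Also open, going by these compounds, is whether a longer chain, such as ethoxy, would do so at either place on the ring.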